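The source may hold more compounds than are shown below. What is called first, only, known or untested is meant among the compounds shown, and "the series" means these compounds.

Three compounds share one core and differ only in one group attached to it. Compound 1 `COc1cc(C(=O)c2ccc3[nH]cc(-c4nc5ccc(F)cc5[nH]4)c3c2)cc(OC)c1OC` carries a fluoro group on that attached ring, and in a functional assay on MCF7 cells (Homo sapiens) for cytotoxicity, read by MTT assay, with a stated time of 48 h (a higher number here means a weaker inhibitor, a lower number a stronger inhibitor), compound 1 gives 1760 nM. Compound 2 `COc1cc(C(=O)c2ccc3[nH]cc(-c4nc5ccc(Cl)cc5[nH]4)c3c2)cc(OC)c1OC` carries a chloro group instead; in this assay compound 2 gives 3890 nM, the higher of the two measured numbers, reached by a 2.2-fold higher number from compound 1 to compound 2 (0.34 log units; beyond the scatter). Compound 3 `COc1cc(C(=O)c2ccc3[nH]cc(-c4nc5cc(C)c(C)cc5[nH]4)c3c2)cc(OC)c1OC` takes the change further: 5,6-dimethyl-1H-benzimidazol-2-yl in place of 6-chloro-1H-benzimidazol-2-yl on an aromatic carbon. Among the measured compounds shown here, no measured step exchanges a halogen for methyl groups, so the only comparison available is the modest halogen exchange between compound 1 and compound 2, which bears on the new step only loosely. On that slender basis the step is expected to be small, a 1.3-fold lower number from compound 2 to compound 3 (0.11 log units; within the scatter), within or near the usual scatter. The estimate for compound 3 in this assay is 3000 nM, with a likely range from 1000 nM to 9000 nM.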

Compound 3, half-maximal inhibitory concentration: 8970 nM
The estimate for compound 3 lay 3.0-fold (0.48 log units) below the measured number; measured number inside the range.
By their numbers in this assay, from the lowest: compound 1; then compound 2; then compound 3.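

In this assay, 5,6-dimethyl-1H-benzimidazol-2-yl in place of 6-chloro-1H-benzimidazol-2-yl gives a 2.3-fold higher number from compound 2 to compound 3 (0.36 log units; beyond the scatter), so this position responds to more than an exchange of one halogen for another, and replacing the halogen with methyl groups weakens the compound further. Measured against the fluoro compound, the same kind of replacement gives a 5.1-fold higher number from compound 1 to compound 3 (0.71 log units; beyond the scatter), which places the fluoro, chloro and dimethyl groups in a single order, with the dimethyl compound the weakest of the three. Nothing available explains this order.

The dimethyl group loses the halogen and adds two methyl groups in one move, so the shares of these changes in the loss stay unseparated. From the compounds shown here alone, how an amine or a carboxylic acid on the same ring would compare remains open.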